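The compounds below may be only part of what the source reports. "The series", "measured", "known", "first", "only" and "open" are said of these compounds alone.

Three compounds share one core and differ only in the aromatic group attached to the oxygen on a saturated carbon. Compound 1 `Cc1cccc(OC[C@@H]2[C@H]3CC[C@H](c4nc(C(=O)O)cs4)O[C@H]3C[C@H]2O)c1` carries 3-methylphenyl there and gives 3.6 nM in a functional assay on CHO cells for agonist activity at prostaglandin E2 receptor EP2 subtype (Homo sapiens), read by HTRF and cAMP accumulation, with a stated time of 30 min; on this read-out lower numbers stand for an effect already at smaller amounts and higher numbers for an effect only at larger amounts of compound. Compound 2 `O=C(O)c1csc([C@H]2CC[C@@H]3[C@@H](COc4cccc(OC(F)(F)F)c4)[C@H](O)C[C@@H]3O2)n1` gives 0.9 nM, and compound 3 `O=C(O)c1csc([C@H]2CC[C@@H]3[C@@H](COc4ccccc4F)[C@H](O)C[C@@H]3O2)n1` gives 23 nM. Compound 3 thus stands with the highest number of the three, beyond the scatter from both of the others.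

Compound 4 `O=C(O)c1csc([C@H]2CC[C@@H]3[C@@H](COc4cccc(Cl)c4)[C@H](O)C[C@@H]3O2)n1` is the unmeasured member; from compound 3 it differs in one place: 3-chlorophenyl in place of 2-fluorophenyl on an oxygen on a saturated carbon. Within the data shown here, two steps bear on this. The step of a 6.4-fold higher number from compound 1 to compound 3 (0.81 log units; beyond the scatter) shows that moving from 3-methylphenyl to 2-fluorophenyl raised the number, and compound 4 returns to a group substituted in the same manner as compound 1. The step of a 4.0-fold lower number from compound 1 to compound 2 (0.60 log units; beyond the scatter) shows that exchanging the group on that aromatic carbon for another moved the number only modestly. A reversal of the earlier rise is therefore expected, a step of a 6.6-fold lower number from compound 3 to compound 4 (0.82 log units; beyond the scatter) in this assay. Compound 4 is estimated at 3.5 nM, within a range of 1.2 nM to 10 nM.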

Compound 4, half-maximal effective concentration: 6.5 nM
The estimate for compound 4 lay 1.9-fold (0.27 log units) below the measured number; the measured number falls inside the stated range.
By their numbers in this assay, from the lowest: compound 2; then compounds 1 and 4 (each within the scatter of the next); then compound 3.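

In this assay, the step of a 1.8-fold higher number from compound 1 to compound 4 (0.26 log units; within the scatter) means that chloro and methyl cannot be told apart on this aromatic carbon, while the step of a 7.2-fold higher number from compound 2 to compound 4 (0.86 log units; beyond the scatter) shows that trifluoromethoxy and chloro can, so not every exchange there leaves the number unchanged. Among these compounds, the step of a 3.5-fold lower number from compound 3 to compound 4 (0.55 log units; beyond the scatter) adds a second comparison with 2-fluorophenyl, and it is the first to show that a halogen-bearing group can give a lower number than 2-fluorophenyl does. However, this step changes both the halogen and its place on the ring, so it cannot say which of the two matters.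

No measurement shown here explains any of these steps. Still open, as far as these compounds go, is whether 3-fluorophenyl or 2-chlorophenyl would separate the halogen from its place, and how a methoxy group or a nitrile would compare on that aromatic carbon.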